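A few compounds are considered here, and "the series" means these few. Any claim that something is new, unique, unknown or untested is made for them only; others in the source may bear on it.

Compound 1 `CCCCCC(=O)O[C@H]1[C@H](O)[C@H](n2ccc(N)nc2=O)O[C@@H]1CO`: 0.05 ug/mL
Compound 2 `CCCCCCCCCCCCCC(=O)O[C@H]1[C@H](O)[C@H](n2ccc(N)nc2=O)O[C@@H]1CO`: 0.08 ug/mL

In a functional assay on HeLa cells (Homo sapiens) for cytotoxicity, read by cell counting, with a stated time of 48 h (a higher number here means that more compound is needed for the effect, a lower number that less compound is needed), compound 2 stands alongside compound 1, the step of a 1.6-fold higher number from compound 1 to compound 2 (0.20 log units; within the scatter) being within the scatter, so the two cannot be told apart on these numbers. Compound 3 `CCCCCCCCCCCCCCCCCCCCCC(=O)O[C@H]1[C@H](O)[C@H](n2ccc(N)nc2=O)O[C@@H]1CO` repeats the same kind of change on compound 2: octyl in place of hydrogen on a saturated chain carbon, ten or more bonds along the chain from a carbonyl carbon. Going by the values given here, the only step that bears on it, a 1.6-fold higher number from compound 1 to compound 2 (0.20 log units; within the scatter), was small, so no change beyond the scatter is expected in this assay, at most a slight drift to a higher number, which is the expected step of a 1.5-fold higher number from compound 2 to compound 3 (0.18 log units; within the scatter). Compound 3 is therefore estimated at 0.12 ug/mL, within the range 0.04 ug/mL to 0.4 ug/mL.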

Compound 3, concentration for half-maximal effect: 1.1 ug/mL
Beside the measured number, compound 3's estimate is 9.2-fold (0.96 log units) below it; measured number outside the range, above it.
By their numbers in this assay, from the lowest: compounds 1 and 2 (each within the scatter of the next); then compound 3.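

In this assay, lengthening the chain at this position does matter once it is long enough: the second octyl addition gives a 14-fold higher number from compound 2 to compound 3 (1.14 log units; beyond the scatter), while the first gave only a 1.6-fold higher number from compound 1 to compound 2 (0.20 log units; within the scatter). The same change thus has an effect that depends on where it lands. Nothing available explains this jump.

Where between these chain lengths the rise begins remains open, as does whether a longer chain would raise the number further. How an amine or a carboxylic acid at the chain end would behave is also unknown.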